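Replacing the 4-cyanophenyl of compound 1

The source may report more compounds than this note shows. Statements on the series, on what has been measured and on what is new or still open speak of the compounds shown alone.

compound 1 `N#Cc1ccc(/C=C/S(=O)(=O)Cc2ccc(Nc3ncnc4ccccc34)cc2)cc1`: > 100000 nM (a limit)
compound 2 `O=S(=O)(/C=C/c1ccc(Cl)c(Cl)c1)Cc1ccc(Nc2ncnc3ccccc23)cc1`: 14000 nM
compound 3 `O=S(=O)(/C=C/c1ccc(Cl)cc1)Cc1ccc(Nc2ncnc3ccccc23)cc1`: > 100000 nM (a limit)

In a functional assay on OVCAR-8 cells (Homo sapiens) (on this read-out lower numbers stand for stronger inhibition of growth and higher numbers for weaker inhibition of growth), compound 1 gives > 100000 nM, which is a limit and not a number. Compound 1 therefore stands at the top of the readable scale, with the limit of > 100000 nM in this assay, at which 2 of the 3 values shown sit. Compound 3 gives > 100000 nM, which is also a limit.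

The step under study leads to compound 4 `O=S(=O)(/C=C/c1ccc(F)cc1Cl)Cc1ccc(Nc2ncnc3ccccc23)cc1`. It puts 2-chloro-4-fluorophenyl in place of 4-cyanophenyl, on a double-bonded chain carbon bound to a double-bonded chain carbon: 2-chloro-4-fluorophenyl in place of 4-cyanophenyl on a double-bonded chain carbon bound to a double-bonded chain carbon.

Within the data shown here, three measured steps bear on it. Placing 3,4-dichlorophenyl on the same carbon gave an at least 7.1-fold lower number from compound 1 to compound 2 (0.85 log units; beyond the scatter). Hydrogen in place of chloro then gave an at least 7.1-fold higher number from compound 2 to compound 3 (0.85 log units; beyond the scatter), which removes that gain. Chloro in place of cyano gave a step that the two limits leave unreadable from compound 1 to compound 3.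

The entering group of compound 4 matches the 3,4-dichlorophenyl of compound 2 only loosely, so only part of the gain seen with compound 2, at 14000 nM, is expected to carry over. A modest move toward a lower number is expected in this assay, and a reading at the limit remains possible. The expected step is an at least 2.5-fold lower number from compound 1 to compound 4 (0.39 log units; beyond the scatter). For compound 4 the estimated value is 40000 nM, with an expected range of 12000 nM to 100000 nM.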

Compound 4, concentration for 50% growth inhibition: 100000 nM
For compound 4 the middle estimate is 2.5-fold (0.40 log units) below the measured one; measured number inside the range.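

In this assay, 2-chloro-4-fluorophenyl on this carbon does not hold the gain seen with 3,4-dichlorophenyl, with a 7.1-fold higher number from compound 2 to compound 4 (0.85 log units; beyond the scatter). A chloro on the aryl ring is therefore not enough by itself at this position, as compound 3 and compound 4 both show, and among the four groups shown only the 3,4-dichlorophenyl of compound 2 gives a reading clearly off the top of the scale. Compound 4 reads 100000 nM, a number and not a limit. The steps to it give a number no higher from compound 1 to compound 4 (the limit leaves the size open) and a number no higher from compound 3 to compound 4 (the limit leaves the size open), and the size of neither can be read. Compound 1 and compound 3 both stand at a ceiling of the assay: the limit of > 100000 nM in this assay, at which 2 of the 4 values shown sit.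

From the compounds shown here alone, whether the gain of compound 2 belongs to the two chloro groups together or to only one of them stays open, and 3-chlorophenyl or 3,4-difluorophenyl on the same carbon would bear on that. Also open, going by these compounds, is whether any aryl group on this carbon can give a clearly lower number than compound 2, which reads 14000 nM.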